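Swapping the Guanidine-Bearing Side Chain for a Carboxy Group

This account rests on a few compounds, and the source may have more. Where it says the series, first, only, none or still open, it means among the compounds named here.

Of the compounds shown here, two have been measured in a functional assay on HeLa cells (Homo sapiens) for cytotoxicity, read by MTT assay, with a stated time of 48 h; on this read-out lower numbers stand for stronger inhibition and higher numbers for weaker inhibition. Compound 1 `CCCCCCCCCCCCCC(=O)N[C@@H](CCC(=O)O)C(=O)Nc1ccn([C@H]2O[C@@H](CO)[C@H](O)[C@H]2O)c(=O)n1` gives 41000 nM in this assay. Compound 2 `CCCCCCCCCCCCCCCCCC(=O)N[C@@H](CCCNC(=N)N)C(=O)Nc1ccn([C@H]2O[C@@H](CO)[C@H](O)[C@H]2O)c(=O)n1` gives 12100 nM, the lowest of the two numbers, with compound 1 standing at a higher value beyond the usual scatter. Compound 3 `CCCCCCCCCCCCCCCCCC(=O)N[C@@H](CCC(=O)O)C(=O)Nc1ccn([C@H]2O[C@@H](CO)[C@H](O)[C@H]2O)c(=O)n1` has not yet been measured. It differs from compound 2 in one place: a group of 3 heavy atoms (1 carbon, 2 oxygen; no ring) in place of a group of 5 heavy atoms (2 carbon, 3 nitrogen; no ring), on a saturated chain carbon, three bonds along the chain from an amide-type nitrogen and a carbonyl carbon. Among the compounds with values here, no single-change step between measured compounds is available, and compound 2 differs in more than one place from compound 1, which also carries a carboxy group, so the value of compound 1, 41000 nM, is only a loose pointer. Compound 3 is expected to land at a higher number than compound 2, with the step of a 2.3-fold higher number from compound 2 to compound 3 (0.36 log units; beyond the scatter) expected to exceed the scatter but to fall short of the gap to compound 1. The estimate for compound 3 is 28000 nM, within 12000 nM to 70000 nM.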

Compound 3, half-maximal inhibitory concentration: 19000 nM
For compound 3 the middle estimate is 1.5-fold (0.17 log units) above the measured one, and the stated range covers the measured number.
By their numbers in this assay, from the lowest: compounds 2 and 3 (each within the scatter of the next); then compound 1.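

Putting carboxy in place of the group of 5 heavy atoms (2 carbon, 3 nitrogen), on this saturated chain carbon, gives a 1.6-fold higher number from compound 2 to compound 3 (0.20 log units; within the scatter) in this assay and so leaves no difference that can be told from the scatter at this position. With carboxy held in place, the change at the far end of the chain, butyl in place of hydrogen, gives a 2.2-fold lower number from compound 1 to compound 3 (0.33 log units; beyond the scatter) and is a modest step that does exceed the scatter. No measurement at hand bears on the reason for either step.

From the compounds shown here alone, whether an amine at the position of the carboxy would also stay within the scatter of compound 2 remains open. So does the question of how a chain longer than that of compound 3 would read in this assay in the presence of either group.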